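Three Flat Steps Before a Change on the Chain

This account rests on a few compounds, and the source may have more. Where it says the series, first, only, none or still open, it means among the compounds named here.

Compound 3 `COc1cccc(CNCCCNc2ccnc3cc(Cc4cccc(C(F)(F)F)c4)ccc23)c1O` gives 4200 nM in a physicochemical assay for solubility, with a stated time of 18 h, at pH 7.4; a higher number here means a more soluble compound, a lower number a less soluble compound. On that number it stands level with compound 1 `COc1cccc(CNCCCNc2ccnc3cc(Cc4ccccc4)ccc23)c1O`, which gives 4200 nM, and with compound 2 `COc1cccc(CNCCCNc2ccnc3cc(Cc4ccc(C#N)cc4)ccc23)c1O`, which gives 4200 nM. The three measured steps connecting them are all flat: no change at the digits printed from compound 1 to compound 2 (within the scatter), no change at the digits printed from compound 1 to compound 3 (within the scatter) and no change at the digits printed from compound 2 to compound 3 (within the scatter). Neither adding a cyano or a trifluoromethyl to the aromatic carbon nor exchanging one substituted aryl for another on the saturated chain carbon moved the solubility beyond the scatter.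

The step from compound 3 to compound 4 `COc1cccc(CNCCCNc2ccnc3cc(CCc4ccccc4)ccc23)c1O` is a different kind of change: benzyl in place of 3-(trifluoromethyl)phenyl on a saturated chain carbon bound to an aromatic carbon. Seen one bond further out, the same difference reads 3-(trifluoromethyl)benzyl to phenethyl, so the chain between the shared core and the terminal phenyl grows by one carbon while the trifluoromethyl leaves.

Going by the values given here, of the measured steps, the one from compound 1 to compound 3 bears most directly, as it is the reverse removal of the trifluoromethyl, and it was flat; the step from compound 2 to compound 3 was equally flat. Among the compounds with values here, no measured step alters the chain itself. Compound 4 is therefore expected to show no change beyond the scatter, no change at the digits printed from compound 3 to compound 4 (within the scatter). The estimate for compound 4 is 4200 nM, expected to fall between 2000 nM and 8500 nM.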

Compound 4, solubility: 4200 nM
Compound 4: middle estimate and measured number agree at the digits printed, within the range that was stated.
By their numbers in this assay, from the lowest: compounds 1, 2, 3 and 4 (each within the scatter of the next).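

The earlier compounds shown here differed only in what the terminal phenyl carried, whereas this change lengthens the chain itself, and in this assay the result is no change at the digits printed from compound 3 to compound 4 (within the scatter), alongside no change at the digits printed from compound 2 to compound 4 (within the scatter). The cleanest reading of the added carbon alone is the step with benzyl in place of phenyl on a saturated chain carbon bound to an aromatic carbon, since no other group takes part in it, and that step gives no change at the digits printed from compound 1 to compound 4 (within the scatter); across these four compounds, neither a one-carbon extension nor the substituents tried on the terminal phenyl separates one reading from another. No supporting measurement accompanies these readings, so the data offer no explanation for the identical values.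

As far as these compounds go, what remains open is whether this position stays as flat with a group of a different kind, such as a carboxylic acid or a primary amine on the terminal phenyl, or with a longer chain such as 3-phenylpropyl in place of phenethyl. The four compounds also leave open whether changes elsewhere on the molecule, such as on the three-carbon diamine linker or the methoxy-bearing phenol, would shift the reading in this assay.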